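The compounds below may be only part of what the source reports. "The series", "measured", "known", "first", "only" and "open" are said of these compounds alone.

In a functional assay on DU-145 cells (Homo sapiens) for inhibition, read by trypan blue exclusion, with a stated time of 96 h (a higher number here means a weaker inhibitor of growth, a lower number a stronger inhibitor of growth), three compounds have been measured:

compound 1, `Cc1ccc(/C=C(/SCc2ccc(Cl)cc2)C(=O)c2ccc(Cl)cc2)s1`, gives 50000 nM;
compound 2, `Cc1ccc(CS/C(=C/c2ccc(C)s2)C(=O)c2ccc(Cl)cc2)cc1`, gives 50000 nM;
compound 3, `Cc1ccc(CS(=O)(=O)/C(=C/c2cc(C)ccc2C)C(=O)c2ccc(Cl)cc2)cc1`, gives 1000 nM.

Compounds 2 and 1 differ in one place, (chloro in place of methyl on an aromatic carbon), and the step is no change at the digits printed from compound 2 to compound 1 (within the scatter). Compound 3 stands lowest of the three; how its core differs from that of compound 2 is not broken down here. Compound 4, `Cc1ccc(C)c(/C=C(\C(=O)c2ccc(Cl)cc2)S(=O)(=O)Cc2ccc(Cl)cc2)c1`, is not yet measured. It differs from compound 3 by chloro in place of methyl on an aromatic carbon, the same change as between compound 2 and compound 1. Because that step was no change at the digits printed from compound 2 to compound 1 (within the scatter), a similar outcome is expected, so the step from compound 3 to compound 4 in this assay is estimated as no change at the digits printed from compound 3 to compound 4 (within the scatter). For compound 4 the expected value is 1000 nM, with a range from 400 nM to 2500 nM.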

Compound 4, concentration for 50% growth inhibition: 10000 nM
Compound 4: the middle estimate sits 10-fold (1.00 log units) below what was measured, and the stated range ends below it.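

In this assay, the change from 4-methylbenzyl to 4-chlorobenzyl gives a 10-fold higher number from compound 3 to compound 4 (1.00 log units; beyond the scatter), whereas on the core of compound 2 it gives no change at the digits printed from compound 2 to compound 1 (within the scatter). For the compounds shown here, the change therefore does not carry over from one core to the other with a step of the same size: the same change on two cores in this assay, no change at the digits printed (within the scatter) from compound 2 to compound 1 and a 10-fold higher number (1.00 log units; beyond the scatter) from compound 3 to compound 4, 10-fold (1.00 log units) apart, beyond the scatter of two such steps With only one pair on each core, this shows that the outcome of the change depends on the core in these compounds, but not which difference between the cores is responsible or how the change would read on a further core.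

The compounds shown leave open how a fluoro, a methoxy or an amine in the same place would read on either core. They also leave open whether such groups would follow the pattern of compound 2 and compound 1 or that of compound 3 and compound 4.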